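The source may report more compounds than this note shows. Statements on the series, on what has been measured and on what is new or still open speak of the compounds shown alone.

Compound 1 `CC(C)NC(=O)N(O)CC1=Cc2cc(Oc3ccccc3)ccc2OC1`: 63 nM
Compound 2 `C=CCNC(=O)N(O)CC1=Cc2cc(Oc3ccccc3)ccc2OC1`: 44 nM

Both measured compounds share the same core, a hydroxyurea attached through a methylene to a bicyclic ring system carrying a phenoxy group; they differ only in the group on the far amide-type nitrogen. In an assay (Cavia porcellus) for inhibition of Polyunsaturated fatty acid 5-lipoxygenase (Homo sapiens) (on this read-out lower numbers stand for stronger inhibition and higher numbers for weaker inhibition), compound 1 gives 63 nM, and compound 2 gives 44 nM. Among the compounds with values here, the one measured step, a 1.4-fold lower number from compound 1 to compound 2 (0.16 log units; within the scatter), shows that swapping one small chain for another at this position left the read-out essentially unchanged. Compound 2 therefore stands together with compound 1: its number is the smaller of the two, but the gap lies within the scatter, so the two cannot be told apart.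

Compound 3 `CCOC(=O)CNC(=O)N(O)CC1=Cc2cc(Oc3ccccc3)ccc2OC1` is the next compound in this series. The change is ethoxycarbonyl in place of vinyl on a saturated chain carbon bound to an amide-type nitrogen. Within the data shown here, the only step that bears on it is the one from compound 1 to compound 2, which also altered the chain on the amide-type nitrogen and stayed within the scatter; the new change is larger, bringing in an ester where before there was only a hydrocarbon chain, so the measured step is only a loose guide. On that basis no shift beyond the scatter is expected in this assay: the estimated step is a 1.4-fold higher number from compound 2 to compound 3 (0.13 log units; within the scatter). For compound 3 the expected value is 60 nM, with a range from 20 nM to 180 nM.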

Compound 3, half-maximal inhibitory concentration: 74 nM
Beside the measured number, compound 3's estimate is 1.2-fold (0.09 log units) below it, within the range that was stated.
By their numbers in this assay, from the lowest: compounds 2, 1 and 3 (each within the scatter of the next).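

Within the data shown here, the position on the amide-type nitrogen, which had so far been seen only with small hydrocarbon chains, now also holds a chain carrying an ester without a clear shift in this assay: ethoxycarbonyl in place of vinyl gives (a 1.7-fold higher number from compound 2 to compound 3 (0.23 log units; within the scatter)), and (ethoxycarbonyl)methyl in place of isopropyl gives (a 1.2-fold higher number from compound 1 to compound 3 (0.07 log units; within the scatter)). Neither the larger heavy-atom count of the entering group nor its hydrogen-bond acceptors, which vinyl lacks, moves the read-out beyond what repeated measurements would scatter by, so compounds 1, 2 and 3 cannot be told apart here. Nothing available explains why the read-out stays put at this position.

Going by these compounds, the three compounds show only that this read-out is insensitive across these particular chains, so how far that tolerance reaches stays unknown, and a carboxylic acid in place of the ester, an amine on the chain, or a much longer chain could behave differently. On these data alone, it also stays open whether any group at this position can shift the number beyond the scatter in either direction, since every step seen so far lies within it.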